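A few compounds are considered here, and "the series" means these few. Any claim that something is new, unique, unknown or untested is made for them only; others in the source may bear on it.

Of the compounds shown here, two with a shared core have been measured in an assay on cells for activation of Guanylate cyclase soluble subunit alpha-1 (Rattus norvegicus), read by cGMP accumulation and immunoassay, with a stated time of 10 min; on this read-out lower numbers stand for an effect already at smaller amounts and higher numbers for an effect only at larger amounts of compound. Compound 1 `Nc1nc(-c2nn(Cc3ccccc3F)c3ncccc23)nc(N)c1NC(=O)OC1CCC1` gives 0.2 uM. Compound 2 `Nc1nc(-c2nn(Cc3ccccc3F)c3ncccc23)nc(N)c1NC(=O)OCC1CC1` gives 0.2 uM. Among the measured compounds shown here, compound 2 thus stands level with compound 1 on this read-out, and the only measured step, no change at the digits printed from compound 1 to compound 2 (within the scatter), concerns just the group on the oxygen next to the carbonyl and shows no difference that exceeds the scatter.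

Compound 3 `Nc1nc(-c2nn(Cc3ccccc3F)c3ncccc23)nc(N)c1N1CCOC1=O` is not yet measured. Its change from compound 2 is 2-oxo-1,3-oxazolidin-3-yl in place of (cyclopropylmethoxycarbonyl)amino on an aromatic carbon. For the measured compounds named here, the one measured step bears on it only weakly: it exchanged a cyclobutyl for a cyclopropylmethyl and left the minimum effective concentration where it was, whereas here the whole (cyclopropylmethoxycarbonyl)amino group, with its hydrogen-bond donor, gives way to a ring-closed 2-oxo-1,3-oxazolidin-3-yl without a donor. Going by the values given here, no measured pair tells how the assay responds to that. A modest weakening is therefore expected, as the step of a 3.0-fold higher number from compound 2 to compound 3 (0.48 log units; beyond the scatter), with wide uncertainty. For compound 3 the expected value is 0.6 uM, within a range of 0.15 uM to 3 uM.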

Compound 3, minimum effective concentration: 0.3 uM
Compound 3: middle estimate off by 2.0-fold (0.30 log units), on the high side; the range from low to high includes it.
By their numbers in this assay, from the lowest: compounds 1, 2 and 3 (each within the scatter of the next).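

In this assay, replacing the open (cyclopropylmethoxycarbonyl)amino group with the ring-closed 2-oxo-1,3-oxazolidin-3-yl gives a 1.5-fold higher number from compound 2 to compound 3 (0.18 log units; within the scatter) and stays inside the usual scatter, and replacing the matching (cyclobutyloxycarbonyl)amino group gives a 1.5-fold higher number from compound 1 to compound 3 (0.18 log units; within the scatter) with the same reading. The earlier step changed only the group on the oxygen, whereas these steps replace the whole group on the aromatic carbon, so a hydrogen-bond donor at this place is not needed for a value of this size in these compounds, and the smaller ring group serves as well as either open group. Nothing available explains why the read-out holds across this change.

Going by these compounds, whether a plain amine or a carbamate with a longer chain on its oxygen would also hold the value at this place remains open. On these data alone, all three compounds also share the rest of the core, so it is unknown whether the 2-oxo-1,3-oxazolidin-3-yl group would match the open groups if the 2-fluorobenzyl-type group on that core gave way to, for example, a simple methyl group.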